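Swapping the Ester Group: Expected Effect on Cell Toxicity

The source may hold more compounds than are shown below. What is called first, only, known or untested is meant among the compounds shown, and "the series" means these compounds.

Measured so far:
compound 1 `COCC(=O)OCCc1c(-c2ccccc2Cl)c2cc(Cl)ccc2[nH]c1=O`: 74000 nM
compound 2 `CC(=O)N1CCC(C(=O)OCCc2c(-c3ccccc3Cl)c3cc(Cl)ccc3[nH]c2=O)CC1`: 82000 nM

In an ADME assay on HepG2 2.2.15 cells (Homo sapiens) for cytotoxicity (on this read-out higher numbers stand for lower toxicity in this test and lower numbers for higher toxicity in this test), compound 1 gives 74000 nM and compound 2 gives 82000 nM. Compound 2 stands at the top of these two numbers, though its gap to compound 1 lies within the scatter. Compound 3 `O=C(/C=C/c1cccc(C(F)(F)F)c1)OCCc1c(-c2ccccc2Cl)c2cc(Cl)ccc2[nH]c1=O` differs from compound 2 by 2-(3-(trifluoromethyl)phenyl)ethenyl in place of 1-acetylpiperidin-4-yl on a carbonyl carbon. Going by the values given here, the one measured step, a 1.1-fold higher number from compound 1 to compound 2 (0.04 log units; within the scatter), also exchanged the group on this carbonyl carbon and stayed within the scatter. No measurement covers an aromatic group at this place, so the expected step of a 1.4-fold lower number from compound 2 to compound 3 (0.14 log units; within the scatter) is small, towards a somewhat lower number. Compound 3 is therefore estimated at 60000 nM, between 25000 nM and 130000 nM.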

Compound 3, half-maximal cytotoxic concentration: > 1400000 nM
Compound 3 was reported as a limit; the forecaster's own chance of this, stated with the estimate: 20%; middle value at least 23-fold (1.36 log units) away from the limit.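

The value of compound 3 is a limit of the assay, not a number: the limit of > 1400000 nM in this assay, at which 1 of the 3 values shown sits. With 2-(3-(trifluoromethyl)phenyl)ethenyl on this carbonyl carbon, the read-out shows an at least 17-fold higher number from compound 2 to compound 3 (1.23 log units; beyond the scatter) and an at least 18-fold higher number from compound 1 to compound 3 (1.27 log units; beyond the scatter), both pointing to lower toxicity in this test. The earlier exchange gave only a 1.1-fold higher number from compound 1 to compound 2 (0.04 log units; within the scatter), so the group at this place can matter far more than that step showed. As far as these compounds go, it remains open which part of the 2-(3-(trifluoromethyl)phenyl)ethenyl group accounts for the step, and how a plain phenyl, an amine or a carboxylic acid at this place would read.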